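The source may report more compounds than this note shows. Statements on the series, on what has been measured and on what is new or still open speak of the compounds shown alone.

Compound 1 `CC1(/C=C/c2ccccc2C(F)(F)F)C=CC(=O)O1`: 15800 nM
Compound 2 `COc1ccc(/C=C/C2(C)C=CC(=O)O2)c(OC)c1`: 57500 nM

In a functional assay on HT-29 cells (Homo sapiens) for inhibition, read by sulforhodamine B assay, with a stated time of 48 h (a higher number here means a weaker inhibitor of growth, a lower number a stronger inhibitor of growth), compound 2 stands highest of the two at 57500 nM, the weaker inhibitor of growth, while compound 1 gives 15800 nM. Compound 3 `COc1ccccc1/C=C/C1(C)C=CC(=O)O1` has hydrogen in place of methoxy on an aromatic carbon of compound 2: hydrogen in place of methoxy on an aromatic carbon. Going by the values given here, no measured step shows the effect of this change, so the expectation is tentative, resting only on the gap between those two values. A small fall in the number is expected, an estimated 1.5-fold lower number from compound 2 to compound 3 (0.18 log units; within the scatter). Compound 3 is estimated at 38000 nM, with an expected range of 15000 nM to 90000 nM.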

Compound 3, concentration for total growth inhibition: 30800 nM
Compound 3: the middle estimate sits 1.2-fold (0.09 log units) above what was measured; measured number inside the range.
By their numbers in this assay, from the lowest: compounds 1, 3 and 2 (each within the scatter of the next, the first and the last beyond it).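

In this assay, hydrogen in place of methoxy on an aromatic carbon, meta to a methoxy group, gives a 1.9-fold lower number from compound 2 to compound 3 (0.27 log units; within the scatter), so the methoxy group at this position has no effect that stands clear of the scatter. Methoxy in place of trifluoromethyl on an aromatic carbon gives a 1.9-fold higher number from compound 1 to compound 3 (0.29 log units; within the scatter), so that change cannot be told from the scatter either. No other measurement bears on these two steps. The compounds shown leave open whether an amine or a carboxylic acid on that aromatic carbon would give a step beyond the scatter.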